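The source may hold more compounds than are shown below. What is called first, only, known or untested is meant among the compounds shown, and "the series" means these compounds.

In a functional assay on B16 cells (Mus musculus) for cytotoxicity, read by CCK-8 assay, with a stated time of 24 h (a lower number here means a stronger inhibitor, a higher number a weaker inhibitor), compound 1 (`COc1ccccc1Oc1c(N)nc(-c2ccccc2)nc1Cl`) gives 4610 nM while compound 2 (`COc1ccccc1Oc1c(N)nc(-c2ccccc2F)nc1Cl`) gives 13800 nM and compound 3 (`COc1ccccc1Oc1c(N)nc(-c2cccc(Br)c2)nc1Cl`) gives 24600 nM under the same conditions. Compound 2 stands second highest of these three numbers, and the closest comparison is a 1.8-fold higher number from compound 2 to compound 3 (0.25 log units; within the scatter) for its nearest neighbour. Compound 4 (`COc1ccccc1Oc1c(N)nc(-c2ccc(I)cc2)nc1Cl`) has 4-iodophenyl in place of 2-fluorophenyl on an aromatic carbon. Within the data shown here, no iodo compound has been measured, so the guides are the modest halogen steps, a 3.0-fold higher number from compound 1 to compound 2 (0.48 log units; beyond the scatter) and a 5.3-fold higher number from compound 1 to compound 3 (0.73 log units; beyond the scatter) in the same direction. In this assay no step beyond the scatter is therefore expected. The expected size is a 1.1-fold higher number from compound 2 to compound 4 (0.04 log units; within the scatter) for this change. Compound 4 is estimated at 15000 nM within a range from 6000 nM to 38000 nM overall.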

Compound 4, half-maximal inhibitory concentration: 5400 nM
Estimate against measurement, compound 4: 2.8-fold (0.44 log units) above, and the stated range ends above it.
By their numbers in this assay, from the lowest: compounds 1 and 4 (each within the scatter of the next); then compounds 2 and 3 (each within the scatter of the next).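

In this assay, a halogen on this phenyl group does not always raise the number: with iodo in place of hydrogen there is a 1.2-fold higher number from compound 1 to compound 4 (0.07 log units; within the scatter), so compound 4 stays level with compound 1. The 4-iodophenyl group instead recovers what the other two halogenated groups lose, with a 2.6-fold lower number from compound 2 to compound 4 (0.41 log units; beyond the scatter) and a 4.6-fold lower number from compound 3 to compound 4 (0.66 log units; beyond the scatter). No measurement here gives a reason for this difference. Halogen and ring position change together in these steps, so their contributions remain unseparated. A 4-fluorophenyl or 4-bromophenyl group would separate them, and a 4-methoxyphenyl group would show whether a non-halogen group is tolerated there.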